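Swapping a Pyridine for a Methylphenyl on the Ring Nitrogen

This account rests on a few compounds, and the source may have more. Where it says the series, first, only, none or still open, it means among the compounds named here.

Two compounds set the scene. Compound 1 `O=C(Nc1ccccc1Br)N[C@@H]1CCN(c2cccc(C(F)(F)F)n2)C1` is measured in a functional assay for antagonist activity at transient receptor potential cation channel subfamily V member 1 (Rattus norvegicus), read by FLIPR (on this read-out higher numbers stand for higher potency (the scale is a negative logarithm) and lower numbers for lower potency), and gives 7.2. Compound 2 `O=C(Nc1ccccc1Br)N[C@@H]1CCN(c2ccc(Br)cn2)C1` gives 7.2 in this assay, which leaves it level with compound 1 within the usual scatter; the two cannot be told apart on these numbers.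

Compound 3 `Cc1cccc(N2CC[C@@H](NC(=O)Nc3ccccc3Br)C2)c1` has not yet been measured. Its change from compound 2 is 3-methylphenyl in place of 5-bromopyridin-2-yl on an amine nitrogen in a ring. A six-membered ring of carbon only, carrying a methyl group, thus takes the place of a ring that held one nitrogen and a bromine on the amine nitrogen in the five-membered ring.

For the measured compounds named here, no measured pair shows this kind of swap, so the size of the step is open. Losing the ring nitrogen and its hydrogen-bond acceptor is expected to cost a little potency rather than none. The estimated step from compound 2 to compound 3 is a number 0.40 log units lower from compound 2 to compound 3 (beyond the scatter). Compound 3 is therefore expected to give about 6.8 in this assay, with a plausible range from 6.2 to 7.4.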

Compound 3, negative logarithm of the antagonist equilibrium constant: 7.7
For compound 3 the middle estimate is 0.90 log units below the measured one, outside the stated range (above it).
By their numbers in this assay, from the lowest: compounds 1 and 2 (each within the scatter of the next); then compound 3.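

Compounds 1 and 2 carry different rings on the amine nitrogen yet stand level, so on their own they gave no sign that this position could separate compounds. Compound 3 shows that it can: in this assay, 3-methylphenyl in place of 5-bromopyridin-2-yl gives a number 0.50 log units higher from compound 2 to compound 3 (beyond the scatter). A ring of carbon only, with no ring nitrogen, no bromine and no hydrogen-bond acceptor, is therefore tolerated here, and in this pair it is the better of the two groups. No measurement shown here accounts for the rise.

This single step swaps the ring nitrogen and the bromine for a ring carbon and a methyl group all at once, and the attachment pattern on the ring changes with them, so the compounds shown cannot divide the gain among these differences. A 3-bromophenyl ring would keep the bromine without the ring nitrogen, and a methylpyridine would keep the ring nitrogen with a methyl group, so either could help show which part of the change matters.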